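Chloro replacing hydrogen on the benzothiazole-bearing compound 2

A few compounds are considered here, and "the series" means these few. Any claim that something is new, unique, unknown or untested is made for them only; others in the source may bear on it.

For the measured compounds named here, compound 2 `NS(=O)(=O)c1ccc(Nc2ncc(F)c(Nc3nc4ccccc4s3)n2)cc1` is one of two compounds measured in a functional assay on MCF7 cells (Homo sapiens) for antiproliferative activity, read by MTT assay, with a stated time of 48 h; a lower number here means a stronger inhibitor, a higher number a weaker inhibitor. Compound 1 `Cc1ccc2nc(Nc3nc(Nc4ccc(S(N)(=O)=O)cc4)ncc3F)sc2c1` gives 24500 nM in this assay. For compound 2 the assay gives only a limit, > 50000 nM, so no number is known for it. Going by the values given here, the one measured step is an at least 2.0-fold higher number from compound 1 to compound 2 (0.30 log units; that floor lies within the scatter), and it involves (the limit of > 50000 nM in this assay, at which 1 of the 2 values shown sits), so its true size is not known beyond that floor. Compound 3 `NS(=O)(=O)c1ccc(Nc2ncc(F)c(Nc3nc4ccc(Cl)cc4s3)n2)cc1` differs from compound 2 by chloro in place of hydrogen on an aromatic carbon. Among the compounds with values here, no measured step shows a chloro substituent here; the only related step, the loss of a methyl on an aromatic carbon going from compound 1 to compound 2, did not lower the number, and the compound without that substituent sits at the limit. A substituent at such a position is therefore expected, on this evidence, to move the number downward rather than upward, by a step of about an at least 2.0-fold lower number from compound 2 to compound 3 (0.30 log units; that floor lies within the scatter) in this assay, though the limit leaves the size uncertain. Compound 3 is estimated at 25000 nM, within a range from 8000 nM to 80000 nM.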

Compound 3, half-maximal inhibitory concentration: 8340 nM
Compound 3: middle estimate off by 3.0-fold (0.48 log units), on the high side, within the range that was stated.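

In this assay, chloro in place of hydrogen gives an at least 5.9-fold lower number from compound 2 to compound 3 (0.77 log units; beyond the scatter), the first change on this aromatic carbon shown to lie beyond the scatter, whereas the floor of the step that removes methyl lay within it. The comparison of the two substituents at this carbon gives a 2.9-fold lower number from compound 1 to compound 3 (0.47 log units; beyond the scatter), so the change depends on which group is present and not merely on whether the hydrogen is replaced, with chloro giving the lowest number of the three compounds. Compound 2 has only a limit, so the chloro-for-hydrogen step is known only as a floor and the order of methyl and hydrogen stays unresolved: the limit of > 50000 nM in this assay, at which 1 of the 3 values shown sits.

The compounds shown leave open whether bromo, methoxy or an amine on this aromatic carbon would give a lower or a higher number than chloro, so two substituents cannot yet define a trend. They also give no reason for the gain with chloro, and they do not show whether it would carry over to a different core.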